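The compounds below may be only part of what the source reports. "The series", "measured", "known", "first", "only" and "open" are said of these compounds alone.

Measured so far in a functional assay on HepG2 cells (Homo sapiens) for cytotoxicity, read by MTT assay, with a stated time of 48 h; a higher number here means a weaker inhibitor, a lower number a stronger inhibitor:
compound 1 `COc1cc(-c2nnc3n2NC(c2ccco2)C(C(=O)c2ccc(F)cc2)S3)cc(OC)c1OC`: > 100000 nM.
compound 2 `COc1cc(-c2nnc3n2NC(c2cccs2)C(C(=O)c2ccccc2)S3)cc(OC)c1OC`: > 100000 nM.
compound 3 `COc1ccc(C(=O)C2Sc3nnc(-c4cc(OC)c(OC)c(OC)c4)n3NC2c2cccs2)cc1`: 68000 nM.

Compound 1 has in this assay only a limit, > 100000 nM, not a number. Compound 2 likewise stands at a limit, > 100000 nM. For the measured compounds named here, compound 3 is the one compound with a number, 68000 nM. Going by the values given here, the single measured step, an at least 1.4-fold lower number from compound 2 to compound 3 (0.16 log units; that floor lies within the scatter), lies within the scatter and concerns another change on another ring; with two of three values at the limit of > 100000 nM in this assay, at which 2 of the 3 values shown sit, the series shows no resolved movement at all.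

Compound 4 `COc1cc(-c2nnc3n2NC(c2ccco2)C(C(=O)c2ccc([N+](=O)[O-])cc2)S3)cc(OC)c1OC` differs from compound 1 by nitro in place of fluoro on an aromatic carbon, placed para to a large group on the same ring. Among the compounds with values here, no measured step covers a nitro for fluoro change, so nothing beyond the scatter is expected in this assay. Compound 4 is expected near 100000 nM, between 40000 nM and 300000 nM, a step of a number no higher from compound 1 to compound 4 (the limit leaves the size open), and most likely again reported only as a limit.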

Compound 4, half-maximal inhibitory concentration: 87800 nM
Beside the measured number, compound 4's estimate is 1.1-fold (0.06 log units) above it; low and high end bracket the measured number.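

In this assay, the change from 4-fluorophenyl to 4-nitrophenyl gives an at least 1.1-fold lower number from compound 1 to compound 4 (0.05 log units; that floor lies within the scatter), the first step read at this position and the first for this change. Nitro therefore gives a measured number where fluoro gives only a limit, but the step shows no resolved gain. Its full size stays open because the value of compound 1 is a limit: the limit of > 100000 nM in this assay, at which 2 of the 4 values shown sit.

Open, going by these compounds, is whether an amine or a carboxylic acid at this place would move the number beyond the scatter. Also open is whether nitro would give the same reading on the other compounds shown.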